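One Side Group Swapped on a Shared Core

The source may report more compounds than this note shows. Statements on the series, on what has been measured and on what is new or still open speak of the compounds shown alone.

Measured compounds:
compound 1 `CC(C)C(Cc1ncc[nH]1)c1ccc(-c2ccc3cccc(F)c3c2)[nH]c1=O`: 76 nM
compound 2 `CC(C)C(c1ccc(-c2ccc3cccc(F)c3c2)[nH]c1=O)N1CCCCC1=O`: 40 nM
compound 3 `CC(C)C(c1ncc[nH]1)c1ccc(-c2ccc3cccc(F)c3c2)[nH]c1=O`: 33 nM

All three share one core and differ only in the group carried on a saturated chain carbon bound to an aromatic carbon and a saturated chain carbon. In a functional assay on CHO cells for antagonist activity at prostaglandin E2 receptor EP3 subtype (Homo sapiens), read by cAMP accumulation (on this read-out higher numbers stand for weaker inhibition and lower numbers for stronger inhibition), compound 3 gives 33 nM, the lowest number of the three, though compound 2 sits within the scatter of it, and only compound 1 lies beyond it, as a 2.3-fold lower number from compound 1 to compound 3 (0.36 log units; beyond the scatter) shows.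

Compound 4 `CC(C)C(/C=C1\CCNC1=O)c1ccc(-c2ccc3cccc(F)c3c2)[nH]c1=O` is not yet measured. It differs from compound 3 in that (a group of 7 heavy atoms (5 carbon, 1 nitrogen, 1 oxygen; one five-membered non-aromatic ring with 1 hetero atom) in place of a group of 5 heavy atoms (3 carbon, 2 nitrogen; one five-membered aromatic ring with 2 hetero atoms), on a saturated chain carbon bound to an aromatic carbon and a saturated chain carbon).

The steps already seen at this position bear on the new change: a 1.9-fold lower number from compound 1 to compound 2 (0.28 log units; within the scatter), a 1.2-fold lower number from compound 2 to compound 3 (0.08 log units; within the scatter) and a 2.3-fold lower number from compound 1 to compound 3 (0.36 log units; beyond the scatter). Three quite different groups at the same place have moved the number only by small steps, so the position appears tolerant of change. The group entering compound 4 carries a ring bearing a carbonyl and an amide hydrogen, as the group in compound 2 also does, and compound 2 gives 40 nM. A step of no more than modest size is therefore expected, with a slightly higher number somewhat more likely than a lower one: a 1.4-fold higher number from compound 3 to compound 4 (0.13 log units; within the scatter). Compound 4 is expected to give about 45 nM, within a range from 15 nM to 150 nM.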

Compound 4, half-maximal inhibitory concentration: 8.7 nM
Beside the measured number, compound 4's estimate is 5.2-fold (0.71 log units) above it, outside the stated range (below it).
By their numbers in this assay, from the lowest: compound 4; then compounds 3, 2 and 1 (each within the scatter of the next, the first and the last beyond it).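

The position is less forgiving than the first three compounds suggested, since the new group gives a step clearly larger than the scatter in this assay: a 3.8-fold lower number from compound 3 to compound 4 (0.58 log units; beyond the scatter), along with a 4.6-fold lower number from compound 2 to compound 4 (0.66 log units; beyond the scatter) and an 8.7-fold lower number from compound 1 to compound 4 (0.94 log units; beyond the scatter), which makes compound 4 the strongest of the four. The comparison with compound 2 is the most telling, as both groups hold 7 heavy atoms (5 carbon, 1 nitrogen, 1 oxygen) in one non-aromatic ring with 1 hetero atom, so the same atom count does not by itself give the lower number; the groups differ in ring size, five-membered against six-membered, and the entering group has 2 double bonds outside aromatic rings. No measurement here explains why this group stands apart from the other three.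

The compounds shown do not separate the effect of ring size from that of the double bond, so a six-membered ring joined through the same double bond, or the five-membered ring joined through a saturated link, could each give a different answer. As far as these compounds go, how an amine or a carboxylic acid would behave at this place also remains open.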